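Swapping methyl for fluoro on the fused ring

A few compounds are considered here, and "the series" means these few. Any claim that something is new, unique, unknown or untested is made for them only; others in the source may bear on it.

Measured compounds:
- compound 1, `COc1ccc(S(=O)(=O)c2cnc3ccc(C)cc3c2N2CCC(C)CC2)cc1Cl`: 93%
- compound 2, `Cc1ccc2ncc(S(=O)(=O)c3ccc(C)c(Cl)c3)c(N3CCC(C)CC3)c2c1`: 91%

In an assay on isolated protein for displacement of a labelled ligand from metabotropic glutamate receptor 5 (Homo sapiens), with a stated time of 60 min, tested at 1 uM (on this read-out higher numbers stand for more inhibition at the one concentration tested (going by the name of the read-out) and lower numbers for less inhibition), compound 1 gives 93%, the higher of the two numbers, though a number 2 percentage points lower from compound 1 to compound 2 (within the scatter) lies within the scatter, so the two compounds are not distinguishable. Compound 3, `COc1ccc(S(=O)(=O)c2cnc3ccc(F)cc3c2N2CCC(C)CC2)cc1Cl`, has not been measured. It differs from compound 1 in one place: fluoro in place of methyl on an aromatic carbon. Going by the values given here, no measured step touches this position or this exchange; the one step on hand concerns another ring and was small. There is therefore no basis to expect a sizeable move, and compound 3 is estimated near compound 1, with the step of a number 7 percentage points lower from compound 1 to compound 3 (within the scatter) expected, giving an estimate of 86% within 65% to 97%.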

Compound 3, a percentage reported as inhibition, at one concentration (the size of the read-out at that concentration, not a potency): 82%
Compound 3: middle estimate off by 4 percentage points, on the high side, and the stated range covers the measured number.
By their numbers in this assay, from the lowest: compounds 3, 2 and 1 (each within the scatter of the next, the first and the last beyond it).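

Unlike the earlier methoxy-to-methyl step on the other ring, which stayed within the scatter, this exchange produces a change that can be read: in this assay, fluoro in place of methyl gives a number 11 percentage points lower from compound 1 to compound 3 (beyond the scatter). The step is modest, and compound 3 still gives 82% at the one concentration tested, so this methyl can be exchanged without losing most of the inhibition. No measurement here says why the number falls with this exchange.

On these data alone, it remains open how an amine or a nitrile on this same aromatic carbon would compare with methyl and fluoro.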